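The compounds below may be only part of what the source reports. "The series", "measured", "known", "first", "only" and "open" are said of these compounds alone.

For the measured compounds named here, in a functional assay on MDA-MB-231 cells (Homo sapiens) for antiproliferative activity, read by MTT assay, with a stated time of 72 h (on this read-out higher numbers stand for weaker inhibition and lower numbers for stronger inhibition), compound 1 `O=C(O)c1ccc(OCCOc2ccc3cc2COC/C=C/COCc2cccc(c2)-c2ccnc(n2)N3)cc1` gives 54200 nM, the higher of the two exact numbers so far, and compound 2 `O=C(O)c1cccc(NCCOc2ccc3cc2COC/C=C/COCc2cccc(c2)-c2ccnc(n2)N3)c1` gives 21400 nM. Compound 3 `O=C(NO)c1cccc(NCCOc2ccc3cc2COC/C=C/COCc2cccc(c2)-c2ccnc(n2)N3)c1` reads > 50000 nM, which is a limit of the assay and not an exact number. Compound 4 `O=C(CCCCCOc1ccc2cc1COC/C=C/COCc1cccc(c1)-c1ccnc(n1)N2)NO`, not yet measured, alters the side chain of compound 1: 3-(hydroxycarbamoyl)propyl in place of 4-carboxyphenoxy on a saturated chain carbon, two bonds along the chain from an oxygen on an aromatic ring. Going by the values given here, two measured steps bear on this change. Replacing the same side chain gave a 2.5-fold lower number from compound 1 to compound 2 (0.40 log units; beyond the scatter), whereas hydroxyamino in place of hydroxy on the carbonyl carbon gave an at least 2.3-fold higher number from compound 2 to compound 3 (0.36 log units; beyond the scatter). These steps point in opposite directions, so the expectation is loose, leaning towards stronger inhibition: a 4.5-fold lower number from compound 1 to compound 4 (0.65 log units; beyond the scatter). The estimate for compound 4 is 12000 nM, with an expected range of 2000 nM to 50000 nM.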

Compound 4, half-maximal inhibitory concentration: 8070 nM
Compound 4: middle estimate off by 1.5-fold (0.17 log units), on the high side, and the stated range covers the measured number.
By their numbers in this assay, from the lowest: compound 4; then compound 2; then compound 1.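

In this assay, for the compounds shown here, the 3-(hydroxycarbamoyl)propyl chain, which has no ring, gives the lowest number so far, with a 6.7-fold lower number from compound 1 to compound 4 (0.83 log units; beyond the scatter) and a 2.7-fold lower number from compound 2 to compound 4 (0.42 log units; beyond the scatter). The hydroxycarbamoyl end does not set the number alone, since compound 3 carries it on a ring-bearing side chain, and there is an at least 6.1-fold lower number from compound 3 to compound 4 (0.79 log units; beyond the scatter). Compound 3 reads only as a limit: the limit of > 50000 nM in this assay, at which 1 of the 4 values shown sits.

As far as these compounds go, it remains open whether the lower number follows from losing the ring or from the chain itself. A longer chain, or the same chain ending in a carboxylic acid, would help separate these.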